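Iodo Swapped for Methoxy in a Growth Inhibitor

A few compounds are considered here, and "the series" means these few. Any claim that something is new, unique, unknown or untested is made for them only; others in the source may bear on it.

- compound 1 `NC(=O)c1cc(Cl)ccc1NC(=O)COc1ccccc1` in a functional assay on SF-539 cells (Homo sapiens) for inhibition (a higher number here means a weaker inhibitor of growth, a lower number a stronger inhibitor of growth), gives 1800 nM
- compound 2 `NC(=O)c1cc(I)ccc1NC(=O)COc1ccccc1` in this assay gives 249 nM
- compound 3 `COc1ccc(NC(=O)COc2ccccc2)c(C(N)=O)c1` has not yet been measured

In this assay compound 2 stands lowest of the two measured compounds at 249 nM and is the stronger inhibitor of growth. Compound 3 differs from it by one change: methoxy in place of iodo on an aromatic carbon and so has methoxy in place of iodo on an aromatic carbon. For the measured compounds named here, one measured step bears on this place, a 7.2-fold lower number from compound 1 to compound 2 (0.86 log units; beyond the scatter) with iodo in place of chloro. Going by the values given here, no methoxy compound has been measured, so the expectation rests on that single step, and much of that gain is expected to be lost. In this assay the expected step is a 4.8-fold higher number from compound 2 to compound 3 (0.68 log units; beyond the scatter) toward weaker inhibition of growth. The estimate for compound 3 is 1200 nM with a range from 300 nM to 4500 nM until the measurement arrives.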

Compound 3, concentration for 50% growth inhibition: 441 nM
Beside the measured number, compound 3's estimate is 2.7-fold (0.43 log units) above it; the measured number falls inside the stated range.
By their numbers in this assay, from the lowest: compounds 2 and 3 (each within the scatter of the next); then compound 1.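

In this assay, the position para to a large group tolerates more than iodo, showing a 1.8-fold higher number from compound 2 to compound 3 (0.25 log units; within the scatter) when methoxy enters, so the two compounds cannot be told apart. Against chloro, the same methoxy gives a 4.1-fold lower number from compound 1 to compound 3 (0.61 log units; beyond the scatter), so the gain over compound 1 is not confined to iodo. No evidence on hand explains why these groups compare as they do.

Going by these compounds, whether an amine, a carboxylic acid or a longer chain such as ethoxy would keep this level at the same carbon remains open.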